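Moving a Fluorine Around the Pendant Phenyl Ring

The compounds below may be only part of what the source reports. "The series", "measured", "known", "first", "only" and "open" are said of these compounds alone.

Three compounds sharing one core have been run in an ADME assay on the whole organism (Mus musculus, strain Swiss Webster) for pharmacokinetics, read by LC-MS, at a dose of 50 mg/kg by the oral route; on this read-out higher numbers stand for higher exposure at the dose given and lower numbers for lower exposure. Compound 1, `O=C(Nc1ccc(F)c(-c2nc3ncc(-c4ccccc4F)cc3[nH]2)c1)N1CCCC1`, gives 2230 nM in this assay, the second highest of the three numbers. Compound 2, `O=C(Nc1ccc(F)c(-c2nc3ncc(-c4cncc(F)c4)cc3[nH]2)c1)N1CCCC1`, gives 1070 nM, and compound 3, `O=C(Nc1ccc(F)c(-c2nc3ncc(-c4cccnc4F)cc3[nH]2)c1)N1CCCC1`, gives 25600 nM. The steps between them are a 2.1-fold lower number from compound 1 to compound 2 (0.32 log units; beyond the scatter) and an 11-fold higher number from compound 1 to compound 3 (1.06 log units; beyond the scatter), and between the two pyridyl compounds a 24-fold higher number from compound 2 to compound 3 (1.38 log units; beyond the scatter).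

Compound 4, `O=C(Nc1ccc(F)c(-c2nc3ncc(-c4ccc(F)cc4)cc3[nH]2)c1)N1CCCC1`, differs from compound 1 by 4-fluorophenyl in place of 2-fluorophenyl on an aromatic carbon. Going by the values given here, none of the measured steps involves this kind of change: each of them swaps the 2-fluorophenyl for a fluoropyridinyl group rather than shifting the fluorine within a phenyl ring. Among the compounds with values here, the two steps from compound 1 show that exchanging the ring itself can move the number modestly, as in a 2.1-fold lower number from compound 1 to compound 2 (0.32 log units; beyond the scatter), or a great deal, as in an 11-fold higher number from compound 1 to compound 3 (1.06 log units; beyond the scatter); a shift of the fluorine alone has no measured precedent here. With nothing pointing either way, compound 4 is expected to sit near compound 1, with a step estimated as a 1.1-fold higher number from compound 1 to compound 4 (0.05 log units; within the scatter), which may well lie within the scatter. The estimate for compound 4 is 2500 nM, with a range from 800 nM to 8000 nM.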

Compound 4, maximal plasma concentration: 6270 nM
For compound 4 the middle estimate is 2.5-fold (0.40 log units) below the measured one; measured number inside the range.
By their numbers in this assay, from the lowest: compound 2; then compound 1; then compound 4; then compound 3.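

In this assay, going by these compounds alone, the shift of the fluorine alone, with the same atoms joined differently, is enough to give a 2.8-fold higher number from compound 1 to compound 4 (0.45 log units; beyond the scatter) and thus the first measured step at this aromatic carbon in which the ring stays carbon only. It also shows that the ring type alone does not set the order of the numbers: the carbon-only 4-fluorophenyl group gives a 5.9-fold higher number from compound 2 to compound 4 (0.77 log units; beyond the scatter) against the 5-fluoropyridin-3-yl group and a 4.1-fold lower number from compound 3 to compound 4 (0.61 log units; beyond the scatter) against the 2-fluoropyridin-3-yl group, so the two phenyl compounds lie between the two pyridyl compounds, which hold the lowest and highest numbers. Nothing available here accounts for these steps, so the change in exposure stands as an observation without an explanation.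

The compounds shown leave open how a plain phenyl ring, with no fluorine, would compare with the two fluorophenyl groups, and whether a chlorine or a methoxy group on the phenyl ring would follow the same order as the fluorine. They also leave open whether the large gap between the pyridyl compounds would persist with a methyl group in place of their fluorine.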